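From Compound 3 to Compound 4 on the Side Chain

The source may hold more compounds than are shown below. What is called first, only, known or untested is meant among the compounds shown, and "the series" means these compounds.

Measured so far:
compound 1 `OC(CCn1nc2c(Br)c(Br)c(Br)c(Br)c2n1)c1cccc(Cl)c1`: 0%
compound 2 `C[C@@H](O)CCn1nc2c(Br)c(Br)c(Br)c(Br)c2n1`: 24%
compound 3 `C[C@H](O)CCn1nc2c(Br)c(Br)c(Br)c(Br)c2n1`: 10%

In a functional assay on CCRF-CEM cells (Homo sapiens) for antiproliferative activity, read by MTT assay, with a stated time of 48 h, tested at 100 uM (a lower number here means a stronger effect, a higher number a weaker effect of the compound at the concentration tested), compound 3 gives 10%, the second highest of the three numbers. Compound 1 gives 0%, within the scatter of compound 3, while compound 2 gives 24%, beyond it. Among the compounds with values here, the only measured step is a number 14 percentage points lower from compound 2 to compound 3 (beyond the scatter), a modest change that rests on (the fact that compounds 2 and 3 differ only in the configuration as drawn). Compound 4 `OCC(O)Cn1nc2c(Br)c(Br)c(Br)c(Br)c2n1` alters the chain itself: 1,2-dihydroxyethyl in place of 2-hydroxypropyl on a saturated chain carbon bound to an aromatic nitrogen. Within the data shown here, no measured step changes the chain in this way, so the stereochemical step gives no direct guide, and all three measured numbers stay low. Compound 4 is therefore expected to remain low. The step of a number 2 percentage points lower from compound 3 to compound 4 (within the scatter) is expected to stay within the scatter. The estimate for compound 4 in this assay is 8%, ranging from 0% to 25%.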

Compound 4, a percentage reported as activity, at one concentration (the size of the read-out at that concentration, not a potency): 1%
For compound 4 the middle estimate is 7 percentage points above the measured one; the range from low to high includes it.
By their numbers in this assay, from the lowest: compounds 1, 4 and 3 (each within the scatter of the next); then compound 2.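

Putting 1,2-dihydroxyethyl in place of 2-hydroxypropyl on a saturated chain carbon bound to an aromatic nitrogen changes the chain itself, and the two comparisons read differently: a number 9 percentage points lower from compound 3 to compound 4 (within the scatter), whereas a number 23 percentage points lower from compound 2 to compound 4 (beyond the scatter). A chain with a second hydroxyl group therefore keeps the low number in this assay, matching compound 3 rather than compound 2. Nothing measured here explains either step.

As far as these compounds go, whether an amine or a carboxylic acid in place of that second hydroxyl group would keep this low number remains open. So does the effect of a longer chain bearing both hydroxyl groups.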